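Swapping the aryl amine on a spirocyclic orexin antagonist

The source may report more compounds than this note shows. Statements on the series, on what has been measured and on what is new or still open speak of the compounds shown alone.

Measured compounds:
- Compound 1, `Cc1nc(C(=O)N2CCC3(CC3)C[C@H]2CNc2ccc(C(F)(F)F)cn2)c(-c2ccccc2)s1`: in a functional assay on HEK293 cells for antagonist activity at Orexin receptor type 2 (Homo sapiens), read by FLIPR and calcium flux (on this read-out higher numbers stand for higher potency (the scale is a negative logarithm) and lower numbers for lower potency), compound 1 gives < 5, which is a limit of the assay, not a number.
- Compound 2, `Cc1ccnc(NC[C@@H]2CC3(CC3)CN2C(=O)c2nc(C)sc2-c2ccccc2)n1`: compound 2 gives 7.
- Compound 3, `Cc1ccc(-n2nccn2)c(C(=O)N2CCC3(CC3)C[C@H]2CNc2ccc(Cl)cn2)c1`: compound 3 gives < 5, again a limit of the assay rather than a number.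

For the measured compounds named here, compound 2 therefore holds the only real number in this set; the other two entries sit at the limit of < 5 in this assay, at which 2 of the 3 values shown sit.

Compound 4, `Cc1nc(C(=O)N2CC3(CC3)C[C@H]2CNc2ccc(Cl)cn2)c(-c2ccccc2)s1`, keeps the core of compound 2 and changes only the group on the amine nitrogen: 5-chloropyridin-2-yl in place of 4-methylpyrimidin-2-yl on an amine nitrogen. Going by the values given here, no pair of measured compounds differs in just one place, so there is no directly comparable step. Compounds 1 and 3, which both carry a pyridine on that nitrogen but differ from compound 2 in other places as well, reach only the limit. On that basis a loss of potency is expected for compound 4, with the step from compound 2 to compound 4 estimated at a number 1.00 log units lower from compound 2 to compound 4 (beyond the scatter). Compound 4 is expected to give about 6, somewhere between 5 and 7.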

Compound 4, negative logarithm of the antagonist equilibrium constant: 7.1
Estimate against measurement, compound 4: 1.10 log units below, and the stated range ends below it.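

In this assay, putting 5-chloropyridin-2-yl in place of 4-methylpyrimidin-2-yl on this amine nitrogen gives a number 0.10 log units higher from compound 2 to compound 4 (within the scatter), so the two compounds cannot be told apart. For the compounds shown here, this is the first direct comparison at this position, and it shows that the core of compound 2 can carry a pyridine on that nitrogen and still give a real number rather than a limit. The pyridine alone therefore cannot explain the entries for compounds 1 and 3, which also differ from compound 4 in other places: the limit of < 5 in this assay, at which 2 of the 4 values shown sit.

The compounds shown leave open which of those other differences matters for compounds 1 and 3. They also leave open how this nitrogen would tolerate a non-aromatic group such as cyclohexyl, or a pyridine carrying methoxy in place of chlorine.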